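Swapping One Halogenated Anilide Tail for Another

This account rests on a few compounds, and the source may have more. Where it says the series, first, only, none or still open, it means among the compounds named here.

Among the measured compounds shown here, compound 2 `O=C(CSc1nc(Nc2ccccc2)c2ccccc2n1)Nc1ccc(Cl)cc1Cl` holds the lower of the two numbers measured so far in a functional assay on NCI-H1975 cells (Homo sapiens) for inhibition, read by MTT assay, with a stated time of 72 h; a lower number here means a stronger inhibitor, a higher number a weaker inhibitor: in this assay compound 2 gives 8410 nM, while compound 1 `O=C(CSc1nc(Nc2ccccc2)c2ccccc2n1)Nc1cccc([N+](=O)[O-])c1` gives 17900 nM. For the measured compounds named here, the single step between them, a 2.1-fold lower number from compound 1 to compound 2 (0.33 log units; beyond the scatter), came from putting 2,4-dichlorophenyl in place of 3-nitrophenyl on the amide-type nitrogen; the shared core stayed the same and only this tail was changed.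

Compound 3 `O=C(CSc1nc(Nc2ccccc2)c2ccccc2n1)Nc1ccc(F)c(Cl)c1` varies the same tail once more: 3-chloro-4-fluorophenyl in place of 2,4-dichlorophenyl on an amide-type nitrogen. Going by the values given here, both the leaving group and the entering group are phenyl rings carrying two halogens, so this change is smaller in kind than the one measured step, which exchanged a nitro-bearing ring for a chlorine-bearing one. Among the compounds with values here, no measured step compares two halogen patterns against each other, so the direction of any shift is unknown, and a step within the scatter of this assay seems the most likely outcome.

Compound 3 is therefore expected to give about 9000 nM, with a range from 3500 nM to 25000 nM. The expected step is a 1.1-fold higher number from compound 2 to compound 3 (0.03 log units; within the scatter), which would not be beyond the scatter.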

Compound 3, half-maximal inhibitory concentration: 9390 nM
The estimate for compound 3 lay 1.0-fold (0.02 log units) below the measured number; the range from low to high includes it.
By their numbers in this assay, from the lowest: compounds 2, 3 and 1 (each within the scatter of the next, the first and the last beyond it).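

In this assay, exchanging one ring with two halogens for another, 3-chloro-4-fluorophenyl in place of 2,4-dichlorophenyl on the amide-type nitrogen, gives a 1.1-fold higher number from compound 2 to compound 3 (0.05 log units; within the scatter) and so does not separate these two halogen patterns. Among the compounds shown here, the comparison with the nitro-bearing ring adds a caution: 3-chloro-4-fluorophenyl in place of 3-nitrophenyl gives a 1.9-fold lower number from compound 1 to compound 3 (0.28 log units; within the scatter) and stays inside the scatter, whereas a 2.1-fold lower number from compound 1 to compound 2 (0.33 log units; beyond the scatter) lies just beyond it, so the earlier separation from compound 1 is not repeated by compound 3 and the gap between a nitro-bearing tail and a halogen-bearing one is less firm than the single earlier step suggested. The compounds offer no independent evidence that could explain why any of these numbers fall where they do.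

Going by these compounds, all three tails are substituted phenyl rings, so it remains open how this number would respond to an unsubstituted phenyl, a benzyl group, or a ring carrying a methoxy group, an amine or a carboxylic acid. The shared core also stays fixed in all three compounds, which leaves the contribution of its other parts untested here.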